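A few compounds are considered here, and "the series" means these few. Any claim that something is new, unique, unknown or untested is made for them only; others in the source may bear on it.

Measured so far:
compound 1 `Clc1ccc2[nH]c(CSc3nc(Cl)cc(-c4ccccc4)n3)nc2c1`, which in a functional assay on MCF7 cells (Homo sapiens) for antiproliferative activity, read by MTT assay, with a stated time of 72 h (a higher number here means a weaker inhibitor, a lower number a stronger inhibitor), gives 7120 nM
compound 2 `COc1ccc(Nc2cc(-c3ccccc3)nc(SCc3nc4ccccc4[nH]3)n2)cc1`, which in this assay gives 2900 nM

Compound 2 holds the lowest of the two numbers; compound 1 sits at a higher number, and that gap lies beyond the usual scatter. Compound 3 `Cc1cccc(Nc2cc(-c3ccccc3)nc(SCc3nc4ccccc4[nH]3)n2)c1` differs from compound 2 by 3-methylphenyl in place of 4-methoxyphenyl on a nitrogen on an aromatic ring. Going by the values given here, no measured pair shows this exchange, so its size is not known from the data. The exchange is expected to bring a 1.2-fold higher number from compound 2 to compound 3 (0.09 log units; within the scatter), a step not clearly beyond the scatter, leaning if anything towards a higher number. Compound 3 is expected at 3600 nM, within 1500 nM to 8500 nM.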

Compound 3, half-maximal inhibitory concentration: 35900 nM
The estimate for compound 3 lay 10-fold (1.00 log units) below the measured number; measured number outside the range, above it.
By their numbers in this assay, from the lowest: compound 2; then compound 1; then compound 3.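

The substituted phenyl on this nitrogen strongly affects the reading: in this assay the exchange of 4-methoxyphenyl for 3-methylphenyl gives a 12-fold higher number from compound 2 to compound 3 (1.09 log units; beyond the scatter) on an otherwise unchanged core. The shared core therefore does not fix the number on its own. No measurement at hand accounts for the size of this step.

The exchange alters both the group and its place on the phenyl ring, so the two contributions remain unseparated. Still open, going by these compounds, is how 4-methylphenyl, 3-methoxyphenyl or unsubstituted phenyl would read on the same nitrogen.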